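Para-halogen swap on the sulfonyl aryl of compound 1

The source may hold more compounds than are shown below. What is called first, only, known or untested is meant among the compounds shown, and "the series" means these compounds.

Measured so far:
compound 1 `O=C(NCc1ccc(CNS(=O)(=O)c2ccc(Cl)cc2)cc1)c1ccc(CNc2ncccn2)cc1` — 100 nM
compound 2 `O=C(NCc1ccc(CNS(=O)(=O)c2ccccc2F)cc1)c1ccc(CNc2ncccn2)cc1` — 1000 nM
compound 3 `Cc1ccc(S(=O)(=O)NCc2ccc(CNC(=O)c3ccc(CNc4ncccn4)cc3)cc2)cc1` — 100 nM

In an assay on MDA-MB-231 cells for binding affinity to C-X-C chemokine receptor type 4 (Homo sapiens), read by microscopy, with stated times of 10 min and 30 min (on this read-out higher numbers stand for an effect only at larger amounts of compound and lower numbers for an effect already at smaller amounts), compound 1 stands level with compound 3, the two together giving the lowest numbers of the three; compound 2 lies furthest from it, a 10-fold higher number from compound 1 to compound 2 (1.00 log units; beyond the scatter). Compound 4 `O=C(NCc1ccc(CNS(=O)(=O)c2ccc(F)cc2)cc1)c1ccc(CNc2ncccn2)cc1` differs from compound 1 by fluoro in place of chloro on an aromatic carbon, on an aromatic carbon para to a large group. Among the compounds with values here, two steps bear on it: no change at the digits printed from compound 1 to compound 3 (within the scatter) at the same carbon, and a 10-fold higher number from compound 1 to compound 2 (1.00 log units; beyond the scatter), where the halogen also moved to another carbon. Keeping the substituent where it sits argues for a small step; a smaller halogen argues for a drift towards compound 2. For compound 4 a modest rise is expected, a 2.0-fold higher number from compound 1 to compound 4 (0.30 log units; within the scatter), the estimate being 200 nM within 70 nM to 700 nM.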

Compound 4, effective concentration (reported as EC, without a stated level of effect): > 1000 nM
Compound 4: a limit, no number; the forecaster's own chance of this, stated with the estimate: 5%; at least 5.0-fold (0.69 log units) between middle value and limit.
By their numbers in this assay, from the lowest: compounds 1 and 3 (each within the scatter of the next); then compound 2.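

In this assay, this carbon of the sulfonyl aryl ring tolerates chloro and methyl alike but not fluoro: an at least 10-fold higher number from compound 1 to compound 4 (1.00 log units; beyond the scatter), and an at least 10-fold higher number from compound 3 to compound 4 (1.00 log units; beyond the scatter). The size of the step between the two fluoro placements cannot be read, so they stay unranked: a number no lower from compound 2 to compound 4 (the limit leaves the size open). Compound 4 gives a limit, not a number: the limit of > 1000 nM in this assay, at which 1 of the 4 values shown sits.

As far as these compounds go, what bromo, methoxy or trifluoromethyl would give at this carbon stays open. So does whether an unsubstituted phenyl would read with compound 1 or with compound 4.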